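Methoxy to (oxolan-3-yl)oxy in the series

This account rests on a few compounds, and the source may have more. Where it says the series, first, only, none or still open, it means among the compounds named here.

In a functional assay on MCF7 cells (Homo sapiens) for antiproliferative activity, read by MTT assay, with a stated time of 72 h (a lower number here means a stronger inhibitor, a higher number a weaker inhibitor), compound 3 (`COc1cc2ncnc(N3CCCc4ccccc43)c2cc1NC(=O)/C=C/CN1CCCCC1`) gives 3930 nM, which lies within the scatter of both other values: compound 1 (`C/C=C/C(=O)Nc1cc2c(N3CCCc4ccccc43)ncnc2cc1O[C@@H]1CCOC1`) gives 5930 nM and compound 2 (`CC(C)/C=C/C(=O)Nc1cc2c(N3CCCc4ccccc43)ncnc2cc1O[C@@H]1CCOC1`) gives 4680 nM. Compound 4 (`O=C(/C=C/CN1CCCCC1)Nc1cc2c(N3CCCc4ccccc43)ncnc2cc1O[C@@H]1CCOC1`) has oxolan-3-yl in place of methyl on an oxygen on an aromatic ring. Going by the values given here, no measured step isolates this change. Among the compounds with values here, the only step, a 1.3-fold lower number from compound 1 to compound 2 (0.10 log units; within the scatter), is within the scatter and concerns isopropyl in place of methyl on a chain carbon, though both of its compounds carry the (oxolan-3-yl)oxy group. No step beyond the scatter is therefore expected in this assay. The estimated step is a 1.1-fold higher number from compound 3 to compound 4 (0.03 log units; within the scatter). Compound 4 is estimated at 4200 nM, with an expected range of 2000 nM to 8500 nM.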

Compound 4, half-maximal inhibitory concentration: 4450 nM
For compound 4 the middle estimate is 1.1-fold (0.03 log units) below the measured one; measured number inside the range.
By their numbers in this assay, from the lowest: compounds 3, 4, 2 and 1 (each within the scatter of the next).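

In this assay, (oxolan-3-yl)oxy in place of methoxy on the aromatic ring can now be read directly, and the change stays within the scatter (a 1.1-fold higher number from compound 3 to compound 4 (0.05 log units; within the scatter)). With that group kept, the chain changes also stay within the scatter, for (piperidin-1-yl)methyl in place of isopropyl (a 1.1-fold lower number from compound 2 to compound 4 (0.02 log units; within the scatter)) and piperidin-1-yl in place of hydrogen (a 1.3-fold lower number from compound 1 to compound 4 (0.12 log units; within the scatter)). No supporting data bear on these results.

Still open, from the compounds shown here alone, is whether a longer chain on this oxygen, or an amine such as morpholine in place of piperidine on the side chain, would give a step beyond the scatter.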